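Demethylation of a Phenol Ether on Two Related Cores

The source may hold more compounds than are shown below. What is called first, only, known or untested is meant among the compounds shown, and "the series" means these compounds.

Compound 1 `CCN1C(=O)c2c(nc(C(N)=O)n2Cc2ccc(OC)cc2)N2C1=N[C@@H]1CCC[C@@H]12` gives 2.47 in a physicochemical assay for lipophilicity, measured as octanol-water partition; a higher number here means a more lipophilic compound, a lower number a more polar compound. Compound 2 `CCN1C(=O)c2c(nc(C(N)=O)n2Cc2ccc(O)cc2)N2C1=N[C@@H]1CCC[C@@H]12` carries hydrogen in place of methyl on an oxygen on an aromatic ring and in this assay compound 2 gives 2.2; the step is a number 0.27 log units lower from compound 1 to compound 2 (within the scatter). Compound 3 `CCOc1nc2c(n1Cc1ccc(OC)c(Cl)c1)C(=O)N(CC)C1=N[C@@H]3CCC[C@@H]3N12` is the most lipophilic of the three measured, giving 4.66 in this assay; the difference between its core and that of compound 1 is not broken down here. Compound 4 `CCOc1nc2c(n1Cc1ccc(O)c(Cl)c1)C(=O)N(CC)C1=N[C@@H]3CCC[C@@H]3N12` differs from compound 3 by hydrogen in place of methyl on an oxygen on an aromatic ring, the same change as that from compound 1 to compound 2. Because the earlier change gave a number 0.27 log units lower from compound 1 to compound 2 (within the scatter), the expected step for compound 4 in this assay is a number 0.26 log units lower from compound 3 to compound 4 (within the scatter). Compound 4 is therefore estimated at 4.4, with a range from 4 to 4.8.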

Compound 4, partition coefficient: 4.4
Compound 4: middle estimate and measured number agree at the digits printed; low and high end bracket the measured number.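

In this assay, hydrogen in place of methyl on an oxygen on an aromatic ring gives a number 0.26 log units lower from compound 3 to compound 4 (within the scatter), and the same change on the core of compound 1 gives a number 0.27 log units lower from compound 1 to compound 2 (within the scatter). Both steps lie within the scatter, so across these two pairs the change carries from one core to the other without a step that can be told apart from repeat measurement, but two pairs do not establish a rule for the series. Nothing given here bears on why the two steps match.

The compounds shown leave open whether this would hold with a longer chain, such as propyl, on that oxygen. They also leave open what an amine or a carboxylic acid in place of the hydroxy group would give.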